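This account rests on a few compounds, and the source may have more. Where it says the series, first, only, none or still open, it means among the compounds named here.

Compound 1 `CC[C@@H]1NC(=O)[C@H](CCCNC(=N)N)NC(=O)[C@](C)(NC(=O)C(C)C)CCCCN(C)C(=O)[C@@H](c2ccc(Cl)cc2)NC1=O` is a cyclic peptide that was examined in an ADME assay on microsomes (Mus musculus) for metabolic stability; a lower number here means that the compound disappears faster, a higher number that the compound lasts longer. In this assay compound 1 gives > 1 h, which is a limit of the measurement rather than a number. A second member of the same series, compound 2 `CC[C@@H]1NC(=O)[C@H](CCCNC(=N)N)NC(=O)[C@](C)(NC(=O)C(C)C)CCCNC(=O)[C@@H](c2ccccc2)NC1=O`, was run alongside it. In this assay compound 2 likewise gives > 1 h, again a limit and not a number. Among the compounds with values here, both recorded values therefore sit at the same boundary, namely (the limit of > 1 h in this assay, at which 2 of the 2 values shown sit), so the two compounds cannot be told apart on these figures, and no measured step between them is available.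

The compound that follows is compound 3 `CC[C@@H]1NC(=O)[C@H](CCCNC(=N)N)NC(=O)[C@](C)(NC(=O)C(C)C)CCCCN(C)C(=O)[C@@H](c2ccccc2)NC1=O`. It differs from compound 1 by a single change, (hydrogen in place of chloro on an aromatic carbon), which at the level of the whole group reads as 4-chlorophenyl to phenyl. Within the data shown here, with only limits in hand and no measured step to lean on, the step from compound 1 to compound 3 is expected to be small, within the scatter or at most a modest shortening, a step that the limit leaves unreadable from compound 1 to compound 3. Compound 3 is accordingly estimated to give 1.2 h in this assay, with a range from 0.6 h to 2.5 h.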

Compound 3, half-life: > 1 h
Compound 3 was reported as a limit; the forecaster's own chance of this, stated with the estimate: 60%; the middle value is on the limit's open side.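

In this assay compound 3 gives > 1 h, again a limit and not a number, so no step from compound 1 to compound 3 can be read, and all the compounds shown rest at one boundary: the limit of > 1 h in this assay, at which 3 of the 3 values shown sit.

The compounds shown leave open how long each actually lasts and whether hydrogen in place of chloro alters that.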